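A third half-life alongside two assay limits

The source may report more compounds than this note shows. Statements on the series, on what has been measured and on what is new or still open speak of the compounds shown alone.

Compound 1 `CC(C)C(=O)N/C(=N/c1nccn1C(C)C)Nc1ccc(Cl)c(Cl)c1` and compound 2 `CC(C)n1ccnc1/N=C(/NC(=O)C(C)(C)C)Nc1ccc(Cl)c(Cl)c1` share one core. In an in vitro ADME assay on microsomes from liver (Mus musculus) for metabolic stability, read by LC-MS, tested at 1 uM (a lower number here means that the compound disappears faster, a higher number that the compound lasts longer), compound 1 gives > 1 h, which is a limit of the assay. In this assay compound 2 gives > 1 h, likewise a limit. The step from compound 1 to compound 2, a step that the two limits leave unreadable from compound 1 to compound 2, cannot be sized because of the limit of > 1 h in this assay, at which 2 of the 2 values shown sit.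

Compound 3 `CC(C)(C)C(=O)N/C(=N/c1nccn1C(C)(C)C)Nc1ccc(Cl)c(Cl)c1` differs from compound 2 by methyl in place of hydrogen on a saturated chain carbon bound to an aromatic nitrogen and two saturated chain carbons. Among the compounds with values here, no measured step touches this place, and the single step seen gives no reading. Compound 3 is therefore expected to sit at 1.5 h, ranging from 0.6 h to 4 h. The expected step is a step that the limit leaves unreadable from compound 2 to compound 3, nothing beyond the scatter.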

Compound 3, half-life: > 1 h
Compound 3 ended at the assay's limit; the forecaster's own chance of this, stated with the estimate: 70%; the middle value lies beyond the limit too.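

No step can be read from compound 2 to compound 3, because of the assay limit: the limit of > 1 h in this assay, at which 3 of the 3 values shown sit.

The compounds shown leave open how long compound 1, compound 2 and compound 3 actually last in this assay and whether either added methyl changes that at all.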